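Swapping an amide-bearing chain for a small alcohol

The source may report more compounds than this note shows. Statements on the series, on what has been measured and on what is new or still open speak of the compounds shown alone.

Three compounds share one core and differ only in the group hanging from a triple-bonded carbon. Compound 1 `NC(=O)c1cc(Cl)c2c(Cl)c(C#CCN3CCCC3=O)n([C@H]3CCCNC3)c2n1` carries a (2-oxopyrrolidin-1-yl)methyl there and gives, in a functional assay on KG-1 cells (Homo sapiens) for antiproliferative activity (on this read-out higher numbers stand for an effect only at larger amounts of compound and lower numbers for an effect already at smaller amounts), a value of 178 nM. Compound 2 `CC(O)C#Cc1c(Cl)c2c(Cl)cc(C(N)=O)nc2n1[C@H]1CCCNC1` carries a 1-hydroxyethyl and gives 147 nM. Compound 3 `CC(C)(CC#Cc1c(Cl)c2c(Cl)cc(C(N)=O)nc2n1[C@H]1CCCNC1)C(N)=O` carries a 2-carbamoyl-2-methylpropyl and gives 269 nM. Compound 3 thus holds the highest of the three numbers, yet the gaps are small: a 1.5-fold higher number from compound 1 to compound 3 (0.18 log units; within the scatter) and a 1.8-fold higher number from compound 2 to compound 3 (0.26 log units; within the scatter), so none of the three separates from the others.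

Compound 4 `CC(C)(O)C#Cc1c(Cl)c2c(Cl)cc(C(N)=O)nc2n1[C@H]1CCCNC1` differs from compound 3 in this way: 1-hydroxy-1-methylethyl in place of 2-carbamoyl-2-methylpropyl on a triple-bonded carbon. The change removes the amide-bearing chain and puts a compact alcohol in its place, much like the group on compound 2. The most telling comparison is the step from compound 2 to compound 3, which went the opposite way, a 1.8-fold higher number from compound 2 to compound 3 (0.26 log units; within the scatter), and the step of a 1.2-fold lower number from compound 1 to compound 2 (0.08 log units; within the scatter) shows that the alcohol of compound 2 sits close to compound 1 as well.

Compound 4 is therefore expected to give a number near that of compound 2, with a 1.6-fold lower number from compound 3 to compound 4 (0.21 log units; within the scatter). The estimate for compound 4 is 165 nM, within a range of 80 nM to 340 nM.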

Compound 4, half-maximal effective concentration: 302 nM
Compound 4: middle estimate off by 1.8-fold (0.26 log units), on the low side; low and high end bracket the measured number.
By their numbers in this assay, from the lowest: compounds 2, 1, 3 and 4 (each within the scatter of the next, the first and the last beyond it).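

Exchanging the 2-carbamoyl-2-methylpropyl with its 7 heavy atoms for the 1-hydroxy-1-methylethyl with its 4 heavy atoms on the triple-bonded carbon brings no separation in this assay (a 1.1-fold higher number from compound 3 to compound 4 (0.05 log units; within the scatter)), and neither does exchanging the (2-oxopyrrolidin-1-yl)methyl for the same alcohol (a 1.7-fold higher number from compound 1 to compound 4 (0.23 log units; within the scatter)). Having an alcohol on this carbon does not by itself fix the number, since a single methyl in place of hydrogen on the carbon carrying the hydroxyl gives the only step in this set beyond the scatter, and a modest one (a 2.1-fold higher number from compound 2 to compound 4 (0.31 log units; beyond the scatter)). Compounds 1 and 3 lie within the scatter of both alcohols, so the four compounds form no clean ranking, and nothing measured here accounts for the methyl step.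

Going by these compounds, whether the trend from hydrogen to methyl on that carbon continues with an ethyl, or with a ring such as cyclopropyl built on that carbon, remains open. Also open, on these data alone, is how an amine such as dimethylaminomethyl, or a carboxylic acid on a longer chain, would compare at the same triple-bonded carbon.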